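This account rests on a few compounds, and the source may have more. Where it says the series, first, only, none or still open, it means among the compounds named here.

Three compounds have been measured in a functional assay on the whole organism (Tail, strain ICR) with Mus musculus as the target, in the tail flick test, with a stated time of 30 min, at a dose of 25 umol/kg by the oral route; a lower number here means a weaker effect, a higher number a stronger effect of the compound at the dose given:

compound 1, `O=C(CN(c1ncnc2c1ncn2C1CCCCO1)C1CC1)N[C@@H](CCC(=O)OCc1ccccc1)C(=O)OCc1ccccc1`, gives 32.6%
compound 2, `O=C(CN(c1ncnc2c1ncn2C1CCCCO1)C1CC1)NCC(=O)OCc1ccccc1`, gives 55.7%
compound 3, `C[C@@H](O)[C@H](NC(=O)CN(c1ncnc2c1ncn2C1CCCCO1)C1CC1)C(=O)OCc1ccccc1`, gives 23.6%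

Compound 3 has the lowest of the three numbers. Its nearest neighbour is compound 1, and that gap, a number 9 percentage points lower from compound 1 to compound 3 (within the scatter), lies within the scatter. The furthest is compound 2, and the step of a number 32.1 percentage points lower from compound 2 to compound 3 (beyond the scatter) is large and beyond the scatter.

Compound 4, `O=C(CN(c1ncnc2c1ncn2C1CCCCO1)C1CC1)N[C@@H](CO)C(=O)OCc1ccccc1`, has not yet been measured in this assay . It differs from compound 3 by hydrogen in place of methyl on a saturated chain carbon bound to an oxygen on a saturated carbon and a saturated chain carbon.

Two of the measured steps bear on this change, both of them at the saturated chain carbon bound to an amide-type nitrogen and a carbonyl carbon. The step of a number 23.1 percentage points higher from compound 1 to compound 2 (beyond the scatter) shows that a smaller group there goes with a higher number, and a number 32.1 percentage points lower from compound 2 to compound 3 (beyond the scatter) shows that adding 1-hydroxyethyl costs a large amount. Compound 4 keeps the hydroxyl and loses only a methyl, so it sits between compound 3 and compound 2 in size. A modest rise is therefore expected, a number 10.4 percentage points higher from compound 3 to compound 4 (beyond the scatter), though the loss of a single carbon may also leave the number within the scatter. Compound 4 is estimated at 34%, in the range 17% to 52%.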

Compound 4, a percentage reported as activity, at one dose (the size of the read-out at that dose, not a potency): 27.8%
Beside the measured number, compound 4's estimate is 6.2 percentage points above it, and the stated range covers the measured number.
By their numbers in this assay, from the lowest: compounds 3, 4 and 1 (each within the scatter of the next); then compound 2.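

In this assay, cutting 1-hydroxyethyl back to hydroxymethyl gives a number 4.2 percentage points higher from compound 3 to compound 4 (within the scatter), so the methyl on the saturated chain carbon bound to an oxygen on a saturated carbon and a saturated chain carbon makes no difference that can be told from the scatter. The fall seen when a side chain replaces hydrogen on the saturated chain carbon bound to an amide-type nitrogen and a carbonyl carbon is already present with the smaller hydroxymethyl group, at a number 27.9 percentage points lower from compound 2 to compound 4 (beyond the scatter). Hydroxy in place of (benzyloxycarbonyl)methyl, two bonds along the chain from that amide-type nitrogen and carbonyl carbon, gives a number 4.8 percentage points lower from compound 1 to compound 4 (within the scatter), so these very different chain ends also cannot be told apart here. Nothing at hand accounts for these numbers.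

The compounds shown leave open whether the hydroxy group matters at all, since no plain methyl or isopropyl side chain stands among them at this carbon. They also leave open how an amine or a free carboxylic acid at the end of the side chain would compare with hydroxymethyl.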